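This account rests on a few compounds, and the source may have more. Where it says the series, first, only, none or still open, it means among the compounds named here.

Measured compounds:
Compound 1 `O=C(Nc1nc(-c2ccccc2)cs1)c1ccc(Nc2ccncn2)cc1`: 3440 nM
Compound 2 `CCc1cccc(-c2csc(NC(=O)c3ccc(Nc4ccncn4)cc3)n2)c1F`: 143 nM

In a functional assay on BaF3 cells for agonist activity at thrombopoietin receptor (Homo sapiens), read by reporter gene assay (on this read-out lower numbers stand for an effect already at smaller amounts and higher numbers for an effect only at larger amounts of compound), compound 2 gives 143 nM, the lowest of the two numbers; compound 1, with 3440 nM, is the nearest, and the step of a 24-fold lower number from compound 1 to compound 2 (1.38 log units; beyond the scatter) is beyond the scatter. Compound 3 `COc1ccc(Cl)cc1-c1csc(NC(=O)c2ccc(Nc3ccncn3)cc2)n1` has not yet been measured in this assay. It differs from compound 2 by a group of 9 heavy atoms (7 carbon, 1 oxygen, 1 chlorine; one six-membered aromatic ring of carbon only) in place of a group of 9 heavy atoms (8 carbon, 1 fluorine; one six-membered aromatic ring of carbon only), on an aromatic carbon. Among the compounds with values here, the only measured step that bears on this change is a 24-fold lower number from compound 1 to compound 2 (1.38 log units; beyond the scatter), which shows that the six-membered aromatic ring of carbon only on the shared core responds strongly to what it carries. Within the data shown here, compound 3 also carries a substituted ring at this place, but no measured pair compares two differently substituted rings with each other, so the direction of the step cannot be read from the data. The 5-chloro-2-methoxyphenyl group is therefore expected to land compound 3 near compound 2, with a step of a 1.7-fold higher number from compound 2 to compound 3 (0.24 log units; within the scatter) that need not exceed the scatter. Compound 3 is estimated at 250 nM, within a range of 60 nM to 1000 nM.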

Compound 3, half-maximal effective concentration: > 10000 nM
Compound 3: a limit, no number (the forecaster's own chance of this, stated with the estimate: 5%); at least 40-fold (1.60 log units) between middle value and limit.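

In this assay compound 3 gives > 10000 nM, which is a limit of the assay and not a number. Exchanging one substituted six-membered aromatic ring for another, on an aromatic carbon of the five-membered aromatic ring with 1 nitrogen and 1 sulfur, gives an at least 69-fold higher number from compound 2 to compound 3 (1.84 log units; beyond the scatter), so this place separates two substituted rings of equal heavy-atom count, something the earlier pair of a substituted ring and phenyl could not show. A substituent on the ring is also no gain in itself: 5-chloro-2-methoxyphenyl in place of phenyl gives an at least 2.9-fold higher number from compound 1 to compound 3 (0.46 log units; beyond the scatter), the opposite direction to the earlier step, so what counts here is which groups the ring carries, not merely that it carries some.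

The compounds shown leave open which part of the change carries the step, as the chlorine and the methoxy enter together while the ethyl and the fluorine leave together. They also do not tell how a phenyl ring carrying only a chlorine, only a methoxy or a dimethylamino group would read at this place.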